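Swapping an acetyl cap for an isobutyl carbamate

The compounds below may be only part of what the source reports. "The series", "measured", "known", "first", "only" and "open" are said of these compounds alone.

Two compounds share a core that carries two amide groups. Compound 1 `O=C(Nc1ccc2nc(NC(=O)C3CCCCC3)sc2c1)c1c(F)cccc1C(F)(F)F` bears a large, fluorinated aromatic amide on one of them; in a functional assay on WI-38 VA13 cells (Homo sapiens) for cytotoxicity (a higher number here means that more compound is needed for the effect, a lower number that less compound is needed), compound 1 gives 0.032 ug/mL. Compound 2 `CC(=O)Nc1ccc2nc(NC(=O)C3CCCCC3)sc2c1` bears only a small acetamido group at the same position, and in this assay compound 2 gives 2.7 ug/mL, the higher of the two numbers and far from compound 1, well beyond the scatter. Compound 3 `CC(C)COC(=O)Nc1ccc2nc(NC(=O)C3CCCCC3)sc2c1` has not yet been measured. It differs from compound 2 in one place: isobutoxy in place of methyl on a carbonyl carbon, so the change reads acetyl to isobutoxycarbonyl. Within the data shown here, no single-change step between measured compounds exists to lean on. Since compound 1, with its larger group there, gives 0.032 ug/mL, a moderate move toward a lower number is expected in this assay, although it may also stay within the scatter. Compound 3 is expected to give 1 ug/mL, between 0.2 ug/mL and 5 ug/mL. The expected step is a 2.7-fold lower number from compound 2 to compound 3 (0.43 log units; beyond the scatter).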

Compound 3, half-maximal effective concentration: 0.72 ug/mL
Compound 3: the middle estimate sits 1.4-fold (0.14 log units) above what was measured; low and high end bracket the measured number.
By their numbers in this assay, from the lowest: compound 1; then compound 3; then compound 2.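

In this assay, the change from acetyl to isobutoxycarbonyl gives a 3.8-fold lower number from compound 2 to compound 3 (0.57 log units; beyond the scatter). Among these compounds, this is the first single-change step at this position, and it shows that a group with no ring, isobutoxy, is enough to move the number beyond the scatter while the carbonyl and the amide-type nitrogen stay in place. Nothing measured here explains the step.

Isobutoxy brings both more carbon and an oxygen, and this one step cannot tell which of the two matters. The compounds shown include neither a methoxy group nor a plain isobutyl group on that carbonyl carbon, so the separate contributions of the oxygen and the branched chain remain open.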